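Dropping the alpha-methyl from the amide chain

The source may report more compounds than this note shows. Statements on the series, on what has been measured and on what is new or still open speak of the compounds shown alone.

Measured compounds:
`COc1ccc(-c2ccc(C(=O)N[C@H](C)CCCc3cccnc3)cc2Br)cc1OC` — compound 1, 180 nM
`COc1ccc(-c2ccc(C(=O)N[C@H](C)CCCc3cccnc3)cc2[N+](=O)[O-])cc1OC` — compound 2, 200 nM

Of the compounds shown here, two have been measured in an assay (Canis lupus familiaris) for binding affinity to platelet-activating factor receptor (Homo sapiens), read by radioligand binding; a higher number here means a weaker inhibitor, a lower number a stronger inhibitor. Compound 1 gives 180 nM there, and compound 2 gives 200 nM. Going by the values given here, the only step between them, a 1.1-fold higher number from compound 1 to compound 2 (0.05 log units; within the scatter), is a change of nitro in place of bromo on an aromatic carbon, and it lies within the scatter, so the two numbers cannot be told apart.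

Compound 3, `COc1ccc(-c2ccc(C(=O)NCCCCc3cccnc3)cc2Br)cc1OC`, keeps the bromo-bearing core of compound 1 and differs from it only by hydrogen in place of methyl on a saturated chain carbon bound to an amide-type nitrogen and a saturated chain carbon. Among the compounds with values here, no measured step touches this part of the molecule, so the bromo-to-nitro comparison says nothing about what to expect here.

Within the data shown here, with no bearing step to lean on, compound 3 is expected to come out close to compound 1, with a wide range on either side: an estimated 350 nM in this assay, between 120 nM and 1000 nM, which would mean a step of a 1.9-fold higher number from compound 1 to compound 3 (0.29 log units; within the scatter).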

Compound 3, half-maximal inhibitory concentration: 220 nM
Beside the measured number, compound 3's estimate is 1.6-fold (0.20 log units) above it; the range from low to high includes it.
By their numbers in this assay, from the lowest: compounds 1, 2 and 3 (each within the scatter of the next).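

In this assay, the methyl on this saturated chain carbon bound to an amide-type nitrogen and a saturated chain carbon proves dispensable on the bromo-bearing core, at least within the precision of the measurement: putting hydrogen in its place gives a 1.2-fold higher number from compound 1 to compound 3 (0.09 log units; within the scatter). The earlier step spoke only to the bromo and nitro groups on an aromatic carbon, whereas this one shows that the amide chain can lose its methyl without a difference that can be told from the scatter. Nothing available on these compounds offers an explanation for this result.

Going by these compounds, whether hydrogen in place of methyl would read the same way on the nitro-bearing core of compound 2 remains open. Also open, on these data alone, is what an ethyl or a hydroxymethyl group would give on this same chain carbon.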